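Aryl ether chain variation on the shared core: outlook for compound 4

This account rests on a few compounds, and the source may have more. Where it says the series, first, only, none or still open, it means among the compounds named here.

Measured so far:
- compound 1 `CCOc1ccc(C(O)C2OC(=O)c3c(OC)cc(OC)cc32)cc1`: in a functional assay on RAW264.7 cells (Mus musculus) for inhibition, read by Griess assay, with stated times of 1 h and 24 h (on this read-out lower numbers stand for stronger inhibition and higher numbers for weaker inhibition), compound 1 gives > 10000 nM, which is a limit of the assay and not a number.
- compound 2 `CCCCOc1ccc(C(O)C2OC(=O)c3c(OC)cc(OC)cc32)cc1`: compound 2 gives 1800 nM.
- compound 3 `COCCCOc1ccc(C(O)C2OC(=O)c3c(OC)cc(OC)cc32)cc1`: compound 3 gives 1260 nM.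

Within the data shown here, compound 2 holds the highest of the two numbers recorded; its only measured neighbour is compound 3, separated by a 1.4-fold lower number from compound 2 to compound 3 (0.15 log units; within the scatter), so the two are not distinguishable. The informative steps both start from compound 1 and are bounded by the limit of > 10000 nM in this assay, at which 1 of the 3 values shown sits: an at least 5.5-fold lower number from compound 1 to compound 2 (0.74 log units; beyond the scatter) and an at least 7.9-fold lower number from compound 1 to compound 3 (0.89 log units; beyond the scatter). Both show that enlarging the chain beyond ethoxy on the aryl oxygen lowers the number at least modestly, while the exchange of methyl for methoxy at the chain end makes no difference beyond the scatter.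

Compound 4 `COc1cc(OC)c2c(c1)C(C(O)c1ccc(OCc3ccc(OC(F)(F)F)cc3)cc1)OC2=O` differs from compound 2 by 4-(trifluoromethoxy)phenyl in place of propyl on a saturated chain carbon bound to an oxygen on an aromatic ring. Among the measured compounds shown here, no measured step tests an aromatic group at this place, so the expectation rests only on the direction seen with the longer chains. A small further lowering, or none beyond the scatter, is expected. Compound 4 is estimated at 1000 nM, with a range of 300 nM to 4000 nM. The expected step is a 1.8-fold lower number from compound 2 to compound 4 (0.26 log units; within the scatter).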

Compound 4, half-maximal inhibitory concentration: 8140 nM
Estimate against measurement, compound 4: 8.1-fold (0.91 log units) below; measured number above the stated range.
By their numbers in this assay, from the lowest: compounds 3 and 2 (each within the scatter of the next); then compound 4. At a limit, above all of these: compound 1.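

In this assay, 4-(trifluoromethoxy)phenyl in place of propyl gives a 4.5-fold higher number from compound 2 to compound 4 (0.66 log units; beyond the scatter), and the same group in place of 2-methoxyethyl gives a 6.5-fold higher number from compound 3 to compound 4 (0.81 log units; beyond the scatter). The lowering seen with the chains of compounds 2 and 3 therefore does not extend to every larger group on this saturated chain carbon bound to an oxygen on an aromatic ring: compound 4 goes against it, and the number here depends on what enters, not merely on how many heavy atoms enter. Compound 1 gives > 10000 nM, which is a limit and not a number. 4-(trifluoromethoxy)phenyl in place of methyl gives an at least 1.2-fold lower number from compound 1 to compound 4 (0.08 log units; that floor lies within the scatter), and this step is bounded by a limit: the limit of > 10000 nM in this assay, at which 1 of the 4 values shown sits.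

The compounds shown leave open whether the higher number of compound 4 goes with the aromatic ring itself or with the trifluoromethoxy group on it; a plain phenyl at this place would separate the two. Also open, from the compounds shown here alone, is how a longer straight chain, or a chain ending in an amine or a carboxylic acid, would read in this assay.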